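Adding bromines and a methyl to the aryl ether of compound 3

This account rests on a few compounds, and the source may have more. Where it says the series, first, only, none or still open, it means among the compounds named here.

Measured so far in an ADME assay on MT4 cells (Homo sapiens) for cytotoxicity, read by MTT assay, with a stated time of 4 days; on this read-out higher numbers stand for lower toxicity in this test and lower numbers for higher toxicity in this test:
Compound 1, `N#Cc1ccc(Nc2nc(Oc3ccc(Cl)cc3Cl)c3ccccc3n2)cc1`: compound 1 gives 32000 nM
Compound 2, `COc1ccc(Oc2nc(Nc3ccc(C#N)cc3)nc3ccccc23)cc1`: compound 2 gives 340000 nM
Compound 3, `N#Cc1ccc(Nc2nc(Oc3ccc(Br)cc3)c3ccccc3n2)cc1`: compound 3 gives 215000 nM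

Compound 3 sits alongside compound 2 within the scatter, while its step to compound 1 is real: a 6.7-fold higher number from compound 1 to compound 3 (0.83 log units; beyond the scatter). Compound 4, `Cc1cc(Br)cc(Br)c1Oc1nc(Nc2ccc(C#N)cc2)nc2ccccc12`, carries the change (2,4-dibromo-6-methylphenyl in place of 4-bromophenyl on an oxygen on an aromatic ring). This returns to a doubly halogenated ring like that of compound 1, so the steps of a 6.7-fold higher number from compound 1 to compound 3 (0.83 log units; beyond the scatter) and an 11-fold higher number from compound 1 to compound 2 (1.03 log units; beyond the scatter) bear on it, both beyond the scatter and both moving toward higher numbers as halogens were removed. Compound 4 is therefore expected to move the other way, a 4.3-fold lower number from compound 3 to compound 4 (0.63 log units; beyond the scatter). The estimate for compound 4 in this assay is 50000 nM, in a range of 15000 nM to 160000 nM.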

Compound 4, half-maximal cytotoxic concentration: 150000 nM
The estimate for compound 4 lay 3.0-fold (0.48 log units) below the measured number; low and high end bracket the measured number.
By their numbers in this assay, from the lowest: compound 1; then compounds 4, 3 and 2 (each within the scatter of the next, the first and the last beyond it).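

In this assay, the number with 2,4-dibromo-6-methylphenyl on this oxygen stays within the scatter of the 4-bromophenyl one (a 1.4-fold lower number from compound 3 to compound 4 (0.16 log units; within the scatter)). Two halogens on this ring therefore do not by themselves give a number as low as that with 2,4-dichlorophenyl (a 4.7-fold higher number from compound 1 to compound 4 (0.67 log units; beyond the scatter)), although the new ring does fall short of 4-methoxyphenyl (a 2.3-fold lower number from compound 2 to compound 4 (0.36 log units; beyond the scatter)). Still open, on these data alone, is whether the methyl, the kind of halogen or their arrangement accounts for this, and how an amine or a carboxylic acid on this ring would read. Nothing measured here explains these numbers.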